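This account rests on a few compounds, and the source may have more. Where it says the series, first, only, none or still open, it means among the compounds named here.

Among the measured compounds shown here, in a functional assay on DU-145 cells (Homo sapiens) for inhibition, read by trypan blue exclusion, with a stated time of 96 h (on this read-out higher numbers stand for weaker inhibition of growth and lower numbers for stronger inhibition of growth), compound 1 `O=C(/C(=C\c1ccc(F)c([N+](=O)[O-])c1)S(=O)(=O)c1ccc(Br)cc1)c1ccc(Br)cc1` gives 25000 nM, the highest of the two numbers known here. Compound 2 `O=C(/C(=C\c1cc(Cl)c(O)c(Cl)c1)SCc1ccc(Br)cc1)c1ccc(Br)cc1` gives 10000 nM in this assay, a lower number, and the gap between the two lies beyond the usual scatter of this kind of measurement. Compound 3 `O=C(/C(=C\c1ccc(F)cc1)S(=O)(=O)c1ccc(Br)cc1)c1ccc(Br)cc1` has not yet been measured. It differs from compound 1 in one place: hydrogen in place of nitro on an aromatic carbon. For the measured compounds named here, nothing among the measured compounds shows what this change does; compound 2 differs from compound 1 in several places at once and cannot separate this change from the others. Compound 3 is therefore expected to stand close to compound 1 in this assay, with a step of no change at the digits printed from compound 1 to compound 3 (within the scatter) that is expected to be small or none beyond the scatter. The estimate for compound 3 in this assay is 25000 nM, with a range expected from 8000 nM to 80000 nM.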

Compound 3, concentration for 50% growth inhibition: 4000 nM
Compound 3: the middle estimate sits 6.3-fold (0.80 log units) above what was measured; the whole stated range lies above it.
By their numbers in this assay, from the lowest: compound 3; then compound 2; then compound 1.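

In this assay, going from 4-fluoro-3-nitrophenyl to 4-fluorophenyl brings a 6.3-fold lower number from compound 1 to compound 3 (0.80 log units; beyond the scatter), so the group at this place, ortho to a fluoro group, matters: here hydrogen goes with stronger inhibition of growth than nitro. Among the compounds shown here, this is the only comparison in the set that isolates a single change, and it rests on one pair on the core of compound 1. Nothing measured here explains the step.

On these data alone, it remains open whether the step is specific to nitro or would also follow from other groups at this place, such as an amine, a nitrile or a methoxy group. The compounds shown also leave open whether the same change would give a similar step on the core of compound 2.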